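Removal of the piperazine from compound 2 in Substance-P binding

The source may hold more compounds than are shown below. What is called first, only, known or untested is meant among the compounds shown, and "the series" means these compounds.

Measured so far in an assay on CHO cells for displacement of a labelled ligand from Substance-P receptor (Homo sapiens); on this read-out lower numbers stand for stronger inhibition and higher numbers for weaker inhibition:
- compound 1 (`CC(C)(NC(=O)c1ccccc1-c1ccccc1)c1cc(C(F)(F)F)cc(C(F)(F)F)c1`): reported only as a limit of the assay, > 10000 nM.
- compound 2 (`Cc1ccccc1-c1ccc(N2CCN(C)CC2)nc1C(=O)N(C)Cc1cc(C(F)(F)F)cc(C(F)(F)F)c1`): 6.2 nM.

Within the data shown here, compound 2 holds the only real number in this assay; the other value shown is a limit, (the limit of > 10000 nM in this assay, at which 1 of the 2 values shown sits), and compound 1 differs from compound 2 in more than one place, so no single-change step between measured compounds exists. Compound 2 therefore stands alone as the reference point.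

Compound 3 (`Cc1ccccc1-c1cccnc1C(=O)N(C)Cc1cc(C(F)(F)F)cc(C(F)(F)F)c1`) is the next compound to measure. It keeps the whole of compound 2 except for one change: hydrogen in place of 4-methylpiperazin-1-yl on an aromatic carbon, in words hydrogen in place of 4-methylpiperazin-1-yl on an aromatic carbon.

Among the measured compounds shown here, with no measured step to lean on, the expectation is a moderate loss in this assay, larger than the scatter but not a collapse, since compound 2 gives 6.2 nM and the rest of its structure is untouched. The step from compound 2 to compound 3 is estimated at a 3.2-fold higher number from compound 2 to compound 3 (0.51 log units; beyond the scatter). Compound 3 is expected to give about 20 nM, within a range of 4 nM to 100 nM.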

Compound 3, inhibition constant: 3.8 nM
Beside the measured number, compound 3's estimate is 5.3-fold (0.72 log units) above it; the measured number lies below the stated range.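

In this assay, hydrogen in place of 4-methylpiperazin-1-yl on an aromatic carbon gives a 1.6-fold lower number from compound 2 to compound 3 (0.21 log units; within the scatter), so compound 2 and compound 3 cannot be told apart on this read-out. The position next to the ring nitrogen and para to a 2-methylphenyl group therefore accepts the loss of the whole six-membered non-aromatic ring with its 2 hetero atoms and 2 hydrogen-bond acceptors, and a nanomolar-range number in this series does not depend on the 4-methylpiperazin-1-yl group. Among these compounds, nothing measured so far offers a reason for this outcome.

On these data alone, what remains open is whether this position accepts any substituent equally well, since hydrogen and 4-methylpiperazin-1-yl are only two cases, and a carboxylic acid, a primary amine or a methoxy group at the same carbon could read quite differently in this assay. As far as these compounds go, the contribution of the 2-methylphenyl group to the number in this assay also remains open.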